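From 2,4-Dimethylphenyl to 2,4-Difluorophenyl on the Shared Core

A few compounds are considered here, and "the series" means these few. Any claim that something is new, unique, unknown or untested is made for them only; others in the source may bear on it.

Compound 1 `COc1ccccc1-n1nc(-c2ccc(C(F)(F)F)cc2O)nc1-c1ccccc1O` and compound 2 `Cc1ccc(-n2nc(-c3ccc(C(F)(F)F)cc3O)nc2-c2ccccc2O)c(C)c1` share one core and differ only in the group carried on an aromatic nitrogen. In a functional assay on PC-12 cells (Rattus norvegicus) for cytotoxicity, read by MTT assay, with stated times of 2 h and 24 h, tested at 5 uM (a higher number here means a stronger effect of the compound at the concentration tested, a lower number a weaker effect), compound 1 gives 85.6%, and compound 2 gives 93.3%. Going by the values given here, the single known step between them, a number 7.7 percentage points higher from compound 1 to compound 2 (within the scatter), lies within the scatter. Among the compounds with values here, compound 2 therefore holds the highest of the two numbers, yet its only neighbour, compound 1, sits so close that neither can be called the stronger.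

Within the data shown here, compound 3 `Oc1cc(C(F)(F)F)ccc1-c1nc(-c2ccccc2O)n(-c2ccc(F)cc2F)n1` is the unmeasured one. 2,4-difluorophenyl in place of 2,4-dimethylphenyl on an aromatic nitrogen The only step on record alters the very same position and gave a number 7.7 percentage points higher from compound 1 to compound 2 (within the scatter), a change that did not rise above the scatter. Nothing here shows that a different group on this nitrogen shifts the read-out by much, so no step beyond the scatter is expected for compound 3 either. Compound 3 is estimated at 88%, with a range from 74% to 98%. That estimate means an expected step of a number 5.3 percentage points lower from compound 2 to compound 3 (within the scatter), which would stay inside the usual scatter.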

Compound 3, a percentage reported as activity, at one concentration (the size of the read-out at that concentration, not a potency): 83.5%
Estimate against measurement, compound 3: 4.5 percentage points above, within the range that was stated.
By their numbers in this assay, from the lowest: compounds 3, 1 and 2 (each within the scatter of the next).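

Measured in this assay the exchange of 2,4-dimethylphenyl for 2,4-difluorophenyl on the aromatic nitrogen gives a small step (a number 9.8 percentage points lower from compound 2 to compound 3 (within the scatter)), and the exchange of 2-methoxyphenyl for 2,4-difluorophenyl gives another (a number 2.1 percentage points lower from compound 1 to compound 3 (within the scatter)). Going by these compounds alone, the earlier pair offered only one comparison at this position, whereas three different groups can now be compared there, including one that carries fluorine where 2,4-dimethylphenyl carries carbon, and no two of the three compounds can be told apart in this read-out. Nothing available on these compounds speaks to what lies behind this flat result.

On these data alone, all three groups on this nitrogen are substituted phenyl groups, so it remains open whether a phenyl group bearing an amine or a carboxylic acid, or a longer alkyl chain in place of the ring, would move the read-out beyond the scatter. Each number also comes from a single concentration, so the compounds leave open whether one would show a stronger or weaker effect than another at any other concentration, even where their read-outs at the concentration tested cannot be separated.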